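This account rests on a few compounds, and the source may have more. Where it says the series, first, only, none or still open, it means among the compounds named here.

Measured in a functional assay on MCF7 cells (Homo sapiens) for antiproliferative activity, read by MTT assay; a higher number here means a weaker inhibitor, a lower number a stronger inhibitor:
- compound 1 `Cc1c(-n2cc(COc3ccc(/C=C/C(=O)c4cc5c(cc4O)OC(C)(C)CC5)cc3)nn2)cccc1[N+](=O)[O-]`: 176000 nM
- compound 2 `COc1ccc(-n2cc(COc3ccc(/C=C/C(=O)c4ccc5c(c4O)CCC(C)(C)O5)cc3)nn2)c([N+](=O)[O-])c1`: 73100 nM
- compound 3 `CC(=O)c1ccc(-n2cc(COc3ccc(/C=C/C(=O)c4ccc5c(c4O)CCC(C)(C)O5)cc3)nn2)cc1`: 171000 nM

Compound 1 sits at the high end of these numbers, within the scatter of compound 3. Compound 2 has the lower number, beyond the scatter of both.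

Compound 4 `CC1(C)CCc2cc(C(=O)/C=C/c3ccc(OCc4cn(Cc5ccc([N+](=O)[O-])cc5)nn4)cc3)c(O)cc2O1` is still to be measured. It carries 4-nitrobenzyl in place of 2-methyl-3-nitrophenyl on an aromatic nitrogen.

For the measured compounds named here, one measured step bears on this change, a swap of groups on the same kind of nitrogen: a 2.3-fold higher number from compound 2 to compound 3 (0.37 log units; beyond the scatter). It is modest, and it comes from a different core arrangement. Going by the values given here, no measured compound carries 4-nitrobenzyl, so the data give no firm direction. A step beyond the scatter in this assay is not expected, with only a slight lean towards a lower number. The expected size is a 1.5-fold lower number from compound 1 to compound 4 (0.17 log units; within the scatter).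

For compound 4 the estimated value is 120000 nM, with an expected range of 50000 nM to 250000 nM.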

Compound 4, half-maximal inhibitory concentration: "not active" (no number reported)
Nothing numeric was reported for compound 4; no gap can be computed for the estimate.
By their numbers in this assay, from the lowest: compound 2; then compounds 3 and 1 (each within the scatter of the next).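

In this assay, for the compounds shown here, compound 4 is reported as not active, with no number, so no step from compound 1 to compound 4 can be read. Nothing at hand accounts for this result. The compounds shown leave open how far 4-nitrobenzyl and 2-methyl-3-nitrophenyl differ in this series.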